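The source may hold more compounds than are shown below. What is called first, only, known or untested is meant among the compounds shown, and "the series" means these compounds.

Working notes on the sulfation pair.

Compound 3 `CCCCCCCCCCCCCCCCO[C@H]1O[C@H](COCC(CO)(CO)CO)[C@@H](O)[C@H](O)[C@H]1NC(=O)CCCC` carries a hydroxyl on the branched side chain; compound 2 `CCCCCCCCCCCCCCCCO[C@H]1O[C@H](COCC(CO)(CO)COS(=O)(=O)O)[C@@H](O)[C@H](O)[C@H]1NC(=O)CCCC` has it converted to a sulfooxy group. The counted difference is sulfo in place of hydrogen on an oxygen on a saturated carbon. In a functional assay on C6 cells (Rattus norvegicus), read by thymidine incorporation (on this read-out lower numbers stand for stronger inhibition and higher numbers for weaker inhibition), compound 3 gives 18.3 uM, and compound 2 gives 11 uM. The step is a 1.7-fold lower number from compound 3 to compound 2 (0.22 log units; within the scatter), so on this read-out sulfation of the chain hydroxyl leaves the activity essentially where it was.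

Compound 1 `C=CCCC(=O)N[C@H]1[C@@H](OCCc2ccccc2)O[C@H](CO)[C@@H](O)[C@@H]1O` has a different core; the difference between the core of compound 1 and the core of compound 3 is not broken down here. In this assay compound 1 gives only a limit, > 50 uM, which is the boundary of the assay rather than a number, as recorded in the limit of > 50 uM in this assay, at which 1 of the 3 values shown sits.

Compound 4 `C=CCCC(=O)N[C@H]1[C@@H](OCCc2ccccc2)O[C@H](CO)[C@@H](O)[C@@H]1OS(=O)(=O)O` is the sulfated counterpart of compound 1, the difference being (sulfo in place of hydrogen on an oxygen on a saturated carbon). This is the same kind of change as that from compound 3 to compound 2, though not the same: in compound 1 the oxygen sits on a saturated carbon whose other neighbour is a saturated ring carbon, whereas in compound 3 it sits on a saturated carbon whose other neighbour is a saturated chain carbon.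

The step from compound 1 to compound 4 is expected to be a step that the limit leaves unreadable from compound 1 to compound 4, resting on compound 3 to compound 2 giving a 1.7-fold lower number from compound 3 to compound 2 (0.22 log units; within the scatter) and on compound 1 sitting at a limit, (the limit of > 50 uM in this assay, at which 1 of the 3 values shown sits). Compound 4 is therefore estimated at 60 uM in this assay, with a range from 25 uM to 200 uM, and a real chance that only a limit is again returned.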

Compound 4, concentration for 50% inhibition: > 50 uM
Compound 4: no number, only a limit (the forecaster's own chance of this, stated with the estimate: 65%); the middle value lies beyond the limit too.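

Compound 1 and compound 4 each return only a limit of the assay, not a number, so no step can be read between them: the limit of > 50 uM in this assay, at which 2 of the 4 values shown sit.

The compounds shown leave open whether sulfo in place of hydrogen on this oxygen changes the activity of the core of compound 1 in this assay at all, and whether the result for compound 3 and compound 2 carries over to that core.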